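Chain extension on the dihydroxypyrimidine-type core, compound 1 to compound 3

The source may report more compounds than this note shows. Statements on the series, on what has been measured and on what is new or still open speak of the compounds shown alone.

Measured so far:
compound 1, `CCCCCc1nc(O)cc(O)n1` — 3670 nM
compound 2, `Nc1cc(N)nc(SCCCCc2ccccc2)n1` — > 100000 nM

Within the data shown here, in a functional assay on HEK293 cells for agonist activity at G-protein coupled receptor 84 (Homo sapiens), read by calcium flux (on this read-out lower numbers stand for an effect already at smaller amounts and higher numbers for an effect only at larger amounts of compound), compound 1 gives 3670 nM, the only number obtained for the series. For compound 2 the assay gives only a limit, > 100000 nM; this is the case described by the limit of > 100000 nM in this assay, at which 1 of the 2 values shown sits. Compound 3, `CCCCCCCCc1nc(O)cc(O)n1`, is not yet measured. It differs from compound 1 by propyl in place of hydrogen on a saturated chain carbon, five bonds along the chain from an aromatic carbon. A step beyond the scatter, toward smaller numbers in this assay, is expected, a 4.6-fold lower number from compound 1 to compound 3 (0.66 log units; beyond the scatter). For compound 3 an estimate of 800 nM is taken, between 200 nM and 3000 nM.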

Compound 3, half-maximal effective concentration: 11.4 nM
Beside the measured number, compound 3's estimate is 70-fold (1.85 log units) above it; measured number below the stated range.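

In this assay, the saturated chain proves a highly responsive position: propyl in place of hydrogen, five bonds along the chain from an aromatic carbon, gives a 320-fold lower number from compound 1 to compound 3 (2.51 log units; beyond the scatter) with the shared core unchanged. Among these compounds, the earlier compounds offered no step at all, so this is the first sign that a change in the chain alone can move the read-out. Nothing shown gives a cause for this step.

Still open, going by these compounds, is whether a longer chain lowers the number further or raises it again. Also open, on these data alone, is whether a chain carrying a carboxylic acid keeps the effect.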